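The source may report more compounds than this note shows. Statements on the series, on what has been measured and on what is new or still open speak of the compounds shown alone.

Measured so far:
Compound 1, `CC(C)(O)Cn1nc(-c2cc(C3CC3)on2)c2c(N)ncnc21`: 68 nM
Compound 2, `CCCCCCCn1nc(-c2cc(C3CC3)on2)c2c(N)ncnc21`: 96 nM

In an assay on isolated protein for inhibition of proto-oncogene tyrosine-protein kinase receptor Ret (Homo sapiens), read by radiometric assay and 33P incorporation, in the presence of a further agent that is not named here (on this read-out lower numbers stand for stronger inhibition and higher numbers for weaker inhibition), compound 1 gives 68 nM and compound 2 gives 96 nM. Within the data shown here, compound 2 is one of only two measured compounds, and the single step between them, a 1.4-fold higher number from compound 1 to compound 2 (0.15 log units; within the scatter), lies within the scatter, so the two stand level on this read-out.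

Compound 3, `Cn1nc(-c2cc(C3CC3)on2)c2c(N)ncnc21`, differs from compound 2 by hydrogen in place of hexyl on a saturated chain carbon bound to an aromatic nitrogen. Among the measured compounds shown here, the one measured step that bears on this change is a 1.4-fold higher number from compound 1 to compound 2 (0.15 log units; within the scatter): it exchanged one group for another at the same saturated chain carbon bound to an aromatic nitrogen and left the number essentially unchanged. On that basis the removal of the hexyl group is expected to produce no step beyond the scatter, a 1.1-fold lower number from compound 2 to compound 3 (0.03 log units; within the scatter), with the range kept wide because a single step is a thin foundation. Compound 3 is therefore estimated at 90 nM, between 30 nM and 300 nM.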

Compound 3, half-maximal inhibitory concentration: 27 nM
Beside the measured number, compound 3's estimate is 3.3-fold (0.52 log units) above it; measured number below the stated range.
By their numbers in this assay, from the lowest: compound 3; then compounds 1 and 2 (each within the scatter of the next).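

Hydrogen in place of hexyl on a saturated chain carbon bound to an aromatic nitrogen gives a 3.6-fold lower number from compound 2 to compound 3 (0.55 log units; beyond the scatter) in this assay and hydrogen in place of 1-hydroxy-1-methylethyl at the same place gives a 2.5-fold lower number from compound 1 to compound 3 (0.40 log units; beyond the scatter) in the same read-out. The two larger groups had stood level with each other, so this position had seemed indifferent to what it carried, yet the read-out does respond, modestly, when either is cut back to the bare methyl form of compound 3. No measurement offered here accounts for this shift.

The compounds shown leave open whether the number moves gradually with chain length, which an ethyl or a propyl chain would test. As far as these compounds go, how a chain ending in an amine or a carboxylic acid would read also remains open.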